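The source may hold more compounds than are shown below. What is called first, only, known or untested is meant among the compounds shown, and "the series" means these compounds.

Measured so far in a physicochemical assay for solubility, read by HPLC, with a stated time of 24 h; on this read-out higher numbers stand for higher solubility and lower numbers for lower solubility:
compound 1 `CN1CCN(C[C@H]2CN(c3ccc(-n4cc(-c5ccccn5)cn4)c(F)c3)C(=O)O2)CC1` gives 1690000 nM;
compound 2 `O=C1O[C@@H](CN2CCC(O)CC2)CN1c1ccc(-n2cc(-c3ccccn3)cn2)c(F)c1` gives 45900 nM;
compound 3 `O=C1O[C@@H](Cn2ccnc2)CN1c1ccc(-n2cc(-c3ccccn3)cn2)c(F)c1` gives 12300 nM.

Compound 2 stands second highest of the three in this assay: compound 1 sits far higher, as a 37-fold lower number from compound 1 to compound 2 (1.57 log units; beyond the scatter) shows, and compound 3 sits lower, as a 3.7-fold lower number from compound 2 to compound 3 (0.57 log units; beyond the scatter) shows. Compound 4 `O=C1O[C@@H](CSc2cccs2)CN1c1ccc(-n2cc(-c3ccccn3)cn2)c(F)c1` arises from compound 2 by (thiophen-2-yl)sulfanyl in place of 4-hydroxypiperidin-1-yl on a saturated chain carbon bound to a saturated ring carbon. Among the measured compounds shown here, two measured steps bear on this. Exchanging the 4-methylpiperazin-1-yl group gave large drops, a 37-fold lower number from compound 1 to compound 2 (1.57 log units; beyond the scatter) and a 140-fold lower number from compound 1 to compound 3 (2.14 log units; beyond the scatter), and exchanging the 4-hydroxypiperidin-1-yl group for 1H-imidazol-1-yl gave the modest 3.7-fold lower number from compound 2 to compound 3 (0.57 log units; beyond the scatter). A (thiophen-2-yl)sulfanyl group is a further departure from the groups seen so far, so a drop beyond the scatter is expected, estimated as a 15-fold lower number from compound 2 to compound 4 (1.18 log units; beyond the scatter). Compound 4 is therefore expected to give about 3000 nM in this assay, within a range of 500 nM to 15000 nM.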

Compound 4, solubility: 8500 nM
Compound 4: the middle estimate sits 2.8-fold (0.45 log units) below what was measured; the range from low to high includes it.
By their numbers in this assay, from the lowest: compounds 4 and 3 (each within the scatter of the next); then compound 2; then compound 1.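

In this assay, at this saturated chain carbon bound to a saturated ring carbon, a (thiophen-2-yl)sulfanyl group, which has no nitrogen and no hydrogen-bond donor, cannot be told apart from 1H-imidazol-1-yl, with a 1.4-fold lower number from compound 3 to compound 4 (0.16 log units; within the scatter). It also falls short of 4-hydroxypiperidin-1-yl, with a 5.4-fold lower number from compound 2 to compound 4 (0.73 log units; beyond the scatter), and far short of 4-methylpiperazin-1-yl, with a 200-fold lower number from compound 1 to compound 4 (2.30 log units; beyond the scatter), so compound 1 stays alone at the top. Nothing shown gives a measured reason for these gaps.

From the compounds shown here alone, it remains open whether the sulfur link or the thiophene ring sets the value of compound 4, which a phenylsulfanyl group could help separate. Going by these compounds, it is equally open how an open-chain dimethylamino group or a carboxylic acid at this place would compare with compound 1.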